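Amide in place of urea: cytotoxicity of compound 4

A few compounds are considered here, and "the series" means these few. Any claim that something is new, unique, unknown or untested is made for them only; others in the source may bear on it.

Measured compounds and their values in an ADME assay on HS27 cells (Homo sapiens) for cytotoxicity, read by MTT assay; on this read-out lower numbers stand for stronger inhibition and higher numbers for weaker inhibition:
compound 1 `O=C(Nc1ccc(-n2ccc3nc(C(=O)NCc4ccccc4)ccc32)cc1)Nc1ccc(Cl)c(C(F)(F)F)c1` — 3000 nM
compound 2 `COC(=O)c1ccc2c(ccn2-c2ccc(NC(=O)Nc3ccc(Cl)c(C(F)(F)F)c3)cc2)n1` — 8200 nM
compound 3 `COC(=O)c1ccc2c(ccn2-c2cccc(NC(=O)Nc3cccc(C(F)(F)F)c3)c2)n1` — > 10000 nM

Compound 1 gives the lowest of the two numbers that were read as numbers in this assay. Its nearest neighbour is compound 2, reached by putting methoxy in place of benzylamino on a carbonyl carbon: a 2.7-fold higher number from compound 1 to compound 2 (0.44 log units; beyond the scatter). Compound 3 does not give a number in this assay but a limit, (the limit of > 10000 nM in this assay, at which 1 of the 3 values shown sits).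

Compound 4 `O=C(Nc1ccc(-n2ccc3nc(C(=O)NCc4ccccc4)ccc32)cc1)c1cccc(C(F)(F)F)c1` is not yet measured. It differs from compound 1 in one place: 3-(trifluoromethyl)phenyl in place of (4-chloro-3-(trifluoromethyl)phenyl)amino on a carbonyl carbon. Going by the values given here, no measured step touches this part of the molecule; the single measured step concerns the other carbonyl carbon. What can be said is that compound 3, which carries a 3-(trifluoromethyl)phenyl group without chlorine, sits at the limit of this assay, while the chlorine-bearing compounds 1 and 2 give numbers. On that thin basis a weaker cytotoxicity, that is a higher number, is expected for compound 4, with a step of a 1.8-fold higher number from compound 1 to compound 4 (0.26 log units; within the scatter). The estimate for compound 4 in this assay is 5500 nM, with a range from 1800 nM to 16000 nM.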

Compound 4, half-maximal inhibitory concentration: > 10000 nM
Compound 4: only a limit was reported; the forecaster's own chance of this, stated with the estimate: 30%; middle value at least 1.8-fold (0.25 log units) from the limit.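

In this assay compound 4 gives a limit rather than a number, > 10000 nM. Going by these compounds alone, the change on this carbonyl carbon gives an at least 3.3-fold higher number from compound 1 to compound 4 (0.52 log units; beyond the scatter), the first sign that this end of the molecule also affects the read-out; until now, the only measured step was at the other carbonyl carbon, a 2.7-fold higher number from compound 1 to compound 2 (0.44 log units; beyond the scatter), and the new step is a minimum, whereas that one is a measured size. With this result, the limit is no longer confined to a single compound: the limit of > 10000 nM in this assay, at which 2 of the 4 values shown sit.

The change removes the chlorine and the amino nitrogen in a single move, so compound 1 and compound 4 cannot show how much of the step belongs to each, and either the 4-chloro-3-(trifluoromethyl)phenyl group joined directly to the carbonyl carbon or a urea with 3-(trifluoromethyl)phenyl on the core of compound 1 would help to separate them. Going by these compounds, it also remains open whether a quite different group on this carbonyl carbon, such as a morpholine or a short alkyl chain, would give a number in this assay or another limit.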